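Swapping a benzothiazole for a methylpyridine on the amide

The source may hold more compounds than are shown below. What is called first, only, known or untested is meant among the compounds shown, and "the series" means these compounds.

Of the compounds shown here, two sharing one core have been measured in an assay on isolated protein for inhibition of histone deacetylase 4 (Homo sapiens), with a stated time of 1 h; a higher number here means a weaker inhibitor, a lower number a stronger inhibitor. Compound 1 `COc1cccc(NC(=O)COc2ccc3cc(/C=C4/SC(=O)NC4=O)ccc3c2)c1` gives 1600 nM. Going by the values given here, compound 2 `Cc1cccc2sc(NC(=O)COc3ccc4cc(/C=C5/SC(=O)NC5=O)ccc4c3)nc12` gives 1200 nM, the lower of the two numbers, but the only step connecting them, a 1.3-fold lower number from compound 1 to compound 2 (0.12 log units; within the scatter), is within the scatter, so the two compounds cannot be told apart on these numbers. Compound 3 `Cc1cccc(NC(=O)COc2ccc3cc(/C=C4/SC(=O)NC4=O)ccc3c2)n1` is the next compound, and it differs from compound 2 by 6-methylpyridin-2-yl in place of 4-methyl-1,3-benzothiazol-2-yl on an amide-type nitrogen. Among the compounds with values here, the only measured step that speaks to a swap of the group on this amide nitrogen is the one from compound 1 to compound 2, and it stayed within the scatter. On that basis no step beyond the scatter is expected in this assay for the present change, in either direction. Compound 3 is therefore estimated to give about 1400 nM, with a range from 600 nM to 3500 nM. The expected step is a 1.2-fold higher number from compound 2 to compound 3 (0.07 log units; within the scatter), which is within the scatter.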

Compound 3, half-maximal inhibitory concentration: 1100 nM
The estimate for compound 3 lay 1.3-fold (0.10 log units) above the measured number; the range from low to high includes it.
By their numbers in this assay, from the lowest: compounds 3, 2 and 1 (each within the scatter of the next).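

Both a 1.1-fold lower number from compound 2 to compound 3 (0.04 log units; within the scatter) and a 1.5-fold lower number from compound 1 to compound 3 (0.16 log units; within the scatter) lie within the scatter in this assay, so all three compounds now stand level on these numbers. Compound 3 adds something the first pair did not show: 6-methylpyridin-2-yl, with one ring and 7 heavy atoms, cannot be told apart from 4-methyl-1,3-benzothiazol-2-yl, with two rings and 10 heavy atoms, on this amide-type nitrogen. No supporting measurement is available to explain this flat result.

On these data alone, all three groups on this nitrogen are aromatic rings, so it remains open whether an open alkyl chain, or a ring carrying a carboxylic acid or an amine, would produce a step beyond the scatter. As far as these compounds go, whether the same flat result would hold on a different core also remains open.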